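The source may hold more compounds than are shown below. What is called first, only, known or untested is meant among the compounds shown, and "the series" means these compounds.

Values measured in a physicochemical assay for lipophilicity; a higher number here means a more lipophilic compound, a lower number a more polar compound:
Compound 1 `C=C(c1cccc2ccccc12)C1CCC2(CC1)COC(Nc1ccc(F)cc1)OO2`: 5.75
Compound 2 `C=C(c1cccc2ccccc12)C1CCC2(CC1)COC(Nc1cc(Cl)cc(Cl)c1)OO2`: 6.71
Compound 3 `C=C(c1cccc2ccccc12)C1CCC2(CC1)COC(Nc1ccc(OC)cc1)OO2`: 5.46

Two steps fix where compound 3 stands: a number 0.29 log units lower from compound 1 to compound 3 (within the scatter), and a number 1.25 log units lower from compound 2 to compound 3 (beyond the scatter). Its value cannot be told apart from that of compound 1, while compound 2 stands clearly apart from both.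

The next compound, compound 4 `C=C(c1cccc2ccccc12)C1CCC2(CC1)COC(Nc1cccc(C(F)(F)F)c1)OO2`, has not yet been measured. It carries 3-(trifluoromethyl)phenyl in place of 4-methoxyphenyl on an amine nitrogen. Among the compounds with values here, no measured compound carries this group, so the estimate rests on changes at the same amine nitrogen. The large step of a number 1.25 log units lower from compound 2 to compound 3 (beyond the scatter) brought in the same 4-methoxyphenyl that now leaves, and the modest step of a number 0.96 log units higher from compound 1 to compound 2 (beyond the scatter) marks out the span above compound 1.

In this assay, a modest rise beyond the scatter is therefore expected, with the estimated step being a number 0.84 log units higher from compound 3 to compound 4 (beyond the scatter). Compound 4 is estimated at 6.3, with an expected range from 5.9 to 6.7.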

Compound 4, partition coefficient: 6.51
For compound 4 the middle estimate is 0.21 log units below the measured one; the measured number falls inside the stated range.
By their numbers in this assay, from the lowest: compounds 3 and 1 (each within the scatter of the next); then compounds 4 and 2 (each within the scatter of the next).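

In this assay the step of a number 1.05 log units higher from compound 3 to compound 4 (beyond the scatter) and the step of a number 0.76 log units higher from compound 1 to compound 4 (beyond the scatter) show that 3-(trifluoromethyl)phenyl on the amine nitrogen also stands clearly apart from the two groups at the lower end, so the earlier gap no longer rests on 3,5-dichlorophenyl alone. The step of a number 0.20 log units lower from compound 2 to compound 4 (within the scatter) leaves compound 2 and compound 4 indistinguishable, and the four compounds now form two pairs at this position, with compound 1 and compound 3 as the lower pair. Nothing shown here accounts for this division into pairs.

Going by these compounds, all four groups at this nitrogen are substituted phenyl rings, so it remains open where a pyridine ring or a cyclohexyl group would fall in this assay here. On these data alone, it is equally open how a carboxylic acid on the phenyl ring would shift the number.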